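Methyl added on the five-membered ring of compound 2

A few compounds are considered here, and "the series" means these few. Any claim that something is new, unique, unknown or untested is made for them only; others in the source may bear on it.

Measured so far:
compound 1, `COc1ccc(/C(Cl)=C/C=C(\C#N)C(=O)c2c(C)[nH]c3ccccc23)cc1`, 63.1%
compound 2, `N#C/C(=C\C=C(/Cl)c1ccc(Br)cc1)C(=O)c1c[nH]c2ccccc12`, 65.5%

Both compounds were tested in a functional assay for inhibition, with a stated time of 5 min, tested at 1 mM; a higher number here means more inhibition at the concentration tested (going by the name of the read-out), a lower number less inhibition. Going by the values given here, compound 2 has the higher of the two numbers, but its nearest neighbour, compound 1, lies within the scatter of it, so the two are read as alike; no step between them is counted here, since the two structures differ in more than one place.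

Compound 3, `Cc1[nH]c2ccccc2c1C(=O)/C(C#N)=C/C=C(\Cl)c1ccc(Br)cc1`, has not yet been measured. Relative to compound 2 the change is methyl in place of hydrogen on an aromatic carbon. The change leaves the rest of compound 2 untouched.

Among the compounds with values here, no measured pair tells what this methyl does on its own. The only hint is indirect: compound 1 already carries a methyl at this position of its core and sits within the scatter of compound 2. The expected step of a number 1.5 percentage points lower from compound 2 to compound 3 (within the scatter) is therefore small, in no clear direction, and not beyond the scatter, because compound 1 carries the methyl and gives 63.1%. Compound 3 is expected to give 64% in this assay, with a range from 50% to 78%.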

Compound 3, a percentage reported as inhibition, at one concentration (the size of the read-out at that concentration, not a potency): 69.1%
Compound 3: middle estimate off by 5.1 percentage points, on the low side, within the range that was stated.
By their numbers in this assay, from the lowest: compounds 1, 2 and 3 (each within the scatter of the next).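

In this assay, the methyl now has its first direct pair: a number 3.6 percentage points higher from compound 2 to compound 3 (within the scatter) shows that methyl in place of hydrogen on this aromatic carbon, next to the ring nitrogen and next to the ring atom that bears a large group, gives values read as alike at the one concentration tested. Compound 3 also links the other two compounds through a one-place comparison, and a number 6 percentage points higher from compound 1 to compound 3 (within the scatter) shows that bromo in place of methoxy on an aromatic carbon, with the methyl present, likewise stays within the usual scatter. Nothing at hand bears on why these values stay alike.

From the compounds shown here alone, with only these three compounds, all read as alike at a single concentration, the series gives no order among them and no potency, and whether the methyl step would look the same with methoxy in place of bromo remains open. Also open, going by these compounds, is whether a longer chain, an amine or a carboxylic acid in place of the methyl on this carbon would still give a value alike to those of compound 2 and compound 3.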